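Chain length at the core: from propyl to butyl

The source may report more compounds than this note shows. Statements on the series, on what has been measured and on what is new or still open speak of the compounds shown alone.

Measured so far:
Compound 1 `Cc1cc2ccccc2nc1-c1cn(CCC(F)(F)C(F)(F)C(F)(F)C(F)(F)C(F)(F)C(F)(F)C(F)(F)C(F)(F)F)nn1` gives 75.8 ug/mL.
Compound 2 `CCCCCc1cc2ccccc2nc1-c1cn(CCC(F)(F)C(F)(F)C(F)(F)C(F)(F)C(F)(F)C(F)(F)C(F)(F)C(F)(F)F)nn1` reaches only the assay limit, > 100 ug/mL.
Compound 3 `CCCc1cc2ccccc2nc1-c1cn(CCC(F)(F)C(F)(F)C(F)(F)C(F)(F)C(F)(F)C(F)(F)C(F)(F)C(F)(F)F)nn1` reaches only the assay limit, > 100 ug/mL.

Among the compounds with values here, in a functional assay on COLO 205 cells (Homo sapiens) for cytotoxicity, read by MTT assay, with a stated time of 24 h (on this read-out higher numbers stand for weaker inhibition and lower numbers for stronger inhibition), compound 1 is the only member of the series with a number rather than a limit. Compound 3 stands at the limit > 100 ug/mL, which is not a number but the ceiling of the assay. It shares that ceiling with compound 2, so two of the three values sit at the limit of > 100 ug/mL in this assay, at which 2 of the 3 values shown sit.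

The next member, compound 4 `CCCCc1cc2ccccc2nc1-c1cn(CCC(F)(F)C(F)(F)C(F)(F)C(F)(F)C(F)(F)C(F)(F)C(F)(F)C(F)(F)F)nn1`, arises from compound 3 by methyl in place of hydrogen on a saturated chain carbon, three bonds along the chain from an aromatic carbon; seen one bond further out, it is propyl to butyl, placing compound 4 between compound 3 and compound 2 in chain length.

The measured steps that bear on it: an at least 1.3-fold higher number from compound 1 to compound 3 (0.12 log units; that floor lies within the scatter) and an at least 1.3-fold higher number from compound 1 to compound 2 (0.12 log units; that floor lies within the scatter), both floors that lie within the scatter, and a step that the two limits leave unreadable from compound 2 to compound 3, which two limits leave unreadable. Both neighbours of compound 4 by chain length sit at the ceiling, so in this assay the step that the limit leaves unreadable from compound 3 to compound 4 is expected to be unreadable again, with compound 4 most likely reported as a limit rather than a number. The estimate for compound 4 is 150 ug/mL, with a range from 80 ug/mL to 400 ug/mL.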

Compound 4, half-maximal inhibitory concentration: > 100 ug/mL
Compound 4: only a limit was reported; the forecaster's own chance of this, stated with the estimate: 75%; the middle value lies beyond the limit too.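

Going from propyl to butyl at this position does not bring back a number in this assay. Compound 4 gives > 100 ug/mL, which is a limit of the assay and not a number, so every chain longer than the methyl of compound 1 now ends at the same limit, with no exception among the compounds shown. The one step that can be read is an at least 1.3-fold higher number from compound 1 to compound 4 (0.12 log units; that floor lies within the scatter), so the methyl compound is still not shown to differ beyond the scatter from any of its longer-chain partners; the steps among the compounds at the limit cannot be read, and the series now rests mostly on that ceiling: the limit of > 100 ug/mL in this assay, at which 3 of the 4 values shown sit.

As far as these compounds go, what remains open is whether chain length at this position changes the read-out at all, since the true values of the three limited compounds are not known and no trend can be drawn from them. From the compounds shown here alone, it is also open whether an amine or a carboxylic acid on this chain, or a hydrogen in place of the methyl of compound 1, would give a number clearly separated from the limit.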